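Fluoro in place of hydrogen on the core of compound 3

A few compounds are considered here, and "the series" means these few. Any claim that something is new, unique, unknown or untested is made for them only; others in the source may bear on it.

Compound 3 `C1=NCC(CC2Cc3ccccc3C2)N1` is the parent of this step. In an assay on isolated protein for binding affinity to Adrenergic receptor alpha-1 (Rattus norvegicus), read by radioligand binding, in the presence of a further agent that is not named here (on this read-out higher numbers stand for weaker inhibition and lower numbers for stronger inhibition), compound 3 gives 501 nM. Compound 1 `Fc1cccc2c1C=C(CC1CN=CN1)CC2` gives 501 nM, the same number at the digits shown. Compound 2 `Clc1cccc2c1CC(CC1CN=CN1)CC2` gives 316 nM; its gap from compound 3 lies within the scatter, so the three numbers cannot be ordered. Compound 4 `Fc1cccc2c1CC(CC1CN=CN1)C2` differs from compound 3 in one place: fluoro in place of hydrogen on an aromatic carbon. Among the measured compounds shown here, no measured pair shows this change on its own. Compound 1 also carries fluoro and gives 501 nM, level with compound 3, though it differs in the core as well. The step of a 1.1-fold lower number from compound 3 to compound 4 (0.05 log units; within the scatter) is therefore expected to be none beyond the scatter. Compound 4 is estimated at 450 nM, in the range 200 nM to 1100 nM.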

Compound 4, inhibition constant: 158 nM
Beside the measured number, compound 4's estimate is 2.8-fold (0.45 log units) above it; measured number outside the range, below it.
By their numbers in this assay, from the lowest: compounds 4, 2, 1 and 3 (each within the scatter of the next, the first and the last beyond it).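

Fluoro in place of hydrogen on this aromatic carbon is the first single change in the series that can be read on its own. In this assay it gives a 3.2-fold lower number from compound 3 to compound 4 (0.50 log units; beyond the scatter), a modest move towards stronger inhibition. The data on hand give no explanation for this step.

On these data alone, whether a methyl or a methoxy group on this aromatic carbon would move the number the same way stays open. Also open, as far as these compounds go, is whether fluoro on the other aromatic carbons of the ring would give a similar step.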